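A few compounds are considered here, and "the series" means these few. Any claim that something is new, unique, unknown or untested is made for them only; others in the source may bear on it.

Working notes on a small pyridazinone-type set, read in a functional assay on aorta (Rattus norvegicus); a higher number here means a weaker inhibitor, a lower number a stronger inhibitor.

Compound 1 `Cn1nc(CCO)ccc1=O` sits at the assay limit: in this assay compound 1 gives > 100000 nM, a limit and not a number. Compound 2 `Cn1nc(CO)ccc1=O` is likewise only a limit; compound 2 gives > 100000 nM. Compound 3 `O=c1ccc(CO)n[nH]1` also returns only a limit, with compound 3 at > 100000 nM. All three rest on the same point, (the limit of > 100000 nM in this assay, at which 3 of the 3 values shown sit), so no ordering among them can be drawn.

Within the measured pairs, the difference hydroxymethyl in place of hydroxy on a saturated chain carbon bound to an aromatic carbon gives a step that the two limits leave unreadable from compound 2 to compound 1. The cores of compound 2 and compound 3 differ by hydrogen in place of methyl on an aromatic nitrogen, and this gives a step that the two limits leave unreadable from compound 2 to compound 3. Neither step can be sized, since both ends are limits.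

Compound 4 `O=c1ccc(CCO)n[nH]1` has not yet been measured. It differs from compound 3 by hydroxymethyl in place of hydroxy on a saturated chain carbon bound to an aromatic carbon, the same change as that made from compound 2 to compound 1, at the same place in both cases. For the measured compounds named here, because the earlier instance of this change reads a step that the two limits leave unreadable from compound 2 to compound 1, and because every value so far sits at the limit of > 100000 nM in this assay, at which 3 of the 3 values shown sit, the expectation for compound 4 is that this assay again reports a limit; the expected step is a step that the limit leaves unreadable from compound 3 to compound 4. For compound 4 the estimate is 200000 nM, with the likely span from 60000 nM to 1000000 nM.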

Compound 4, half-maximal inhibitory concentration: > 100000 nM
Compound 4 ended at the assay's limit; the forecaster's own chance of this, stated with the estimate: 90%; the middle value does not contradict the limit.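

In this assay compound 4 gives > 100000 nM and this is a limit, not a number. No new step can be read from compound 4 to compound 3 or compound 1, with every value resting on one point: the limit of > 100000 nM in this assay, at which 4 of the 4 values shown sit.

Whether hydroxymethyl in place of hydroxy, or hydrogen in place of methyl on an aromatic nitrogen, changes inhibition in this assay at all stays open with the compounds shown.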